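The source may hold more compounds than are shown below. What is called first, only, known or untested is meant among the compounds shown, and "the series" means these compounds.

In a toxicity assay on HeLa cells (Homo sapiens) for cytotoxicity (on this read-out lower numbers stand for higher toxicity in this test and higher numbers for lower toxicity in this test), compound 1 `COc1nc(-c2ccsc2)ccc1[C@@H](c1ccccc1)[C@@](O)(CCN(C)C)c1cccc2ccccc12` reads > 64 ug/mL as a limit of the assay and not as a number. Compound 2 `COc1ncc(-c2ccccc2)cc1[C@@H](c1ccccc1)[C@@](O)(CCN(C)C)c1cc(F)ccc1F` stands without any figure, with "nd" (no result reported) as its entry in this assay and no number to place it by. Still unmeasured is compound 3 `COc1ncc(-c2ccccc2)cc1[C@@H](c1ccccc1)[C@@](O)(CCN(C)C)c1cc(F)cc(F)c1` which carries the same atoms as compound 2, joined differently. The change is 3,5-difluorophenyl in place of 2,5-difluorophenyl on a saturated chain carbon bound to an oxygen on a saturated carbon and two saturated chain carbons with 3,5-difluorophenyl in place of 2,5-difluorophenyl on a saturated chain carbon bound to an oxygen on a saturated carbon and two saturated chain carbons. Among the compounds with values here, no measured step is available as a guide, and no step beyond the usual scatter is expected in this assay from this change. That expectation rests on compound 1 and its reading of > 64 ug/mL which is again a limit. Compound 3 is estimated at 64 ug/mL with an expected range from 30 ug/mL to 128 ug/mL and the assay may well report only a limit.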

Compound 3, half-maximal cytotoxic concentration: 28.8 ug/mL
Estimate against measurement, compound 3: 2.2-fold (0.35 log units) above; the whole stated range lies above it.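

In this assay compound 3 gives 28.8 ug/mL, while compound 2 has no figure to set against it, and no step can be read between the two. The compounds shown leave open what 3,5-difluorophenyl in place of 2,5-difluorophenyl does to this read-out.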